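The source may report more compounds than this note shows. Statements on the series, on what has been measured and on what is new or still open speak of the compounds shown alone.

Measured compounds in a functional assay on Ehrlich cells (Mus musculus) for cytotoxicity, tested at 25 ug/mL; a lower number here means a weaker effect, a higher number a stronger effect of the compound at the concentration tested:

- compound 1, `COc1cc(N2C(N)=C(C#N)C(c3cccc([N+](=O)[O-])c3)C3=C2CC(C)(C)CC3=O)cc(OC)c1OC`: 20%
- compound 2, `COc1ccccc1C1C(C#N)=C(N)N(c2cc(OC)c(OC)c(OC)c2)C2=C1C(=O)CC(C)(C)C2`: 65%
- compound 3, `COc1cc(N2C(N)=C(C#N)C(c3ccc([N+](=O)[O-])cc3)C3=C2CC(C)(C)CC3=O)cc(OC)c1OC`: 50%

All three share one core and differ only in the aryl group attached to a saturated ring carbon. Compound 3 stands second highest of the three numbers in this assay: compound 2 lies above it, by a number 15 percentage points lower from compound 2 to compound 3 (beyond the scatter) read in reverse, and compound 1 lies below it by a number 30 percentage points higher from compound 1 to compound 3 (beyond the scatter).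

The new compound 4, `COc1cc(N2C(N)=C(C#N)C(c3ccccc3)C3=C2CC(C)(C)CC3=O)cc(OC)c1OC`, removes the nitro group of compound 3 entirely: hydrogen in place of nitro on an aromatic carbon. Within the data shown here, none of the measured steps repeats this change. Moving the nitro from one aromatic position to another gave a number 30 percentage points higher from compound 1 to compound 3 (beyond the scatter), and exchanging the 4-nitrophenyl for a 2-methoxyphenyl gave a number 15 percentage points lower from compound 2 to compound 3 (beyond the scatter). Both show that the aryl substituent matters beyond the scatter, in either direction, so a modest shift is expected for compound 4, most likely downward, with wide uncertainty. Compound 4 is estimated at 40%, within 20% to 65%, a step of a number 10 percentage points lower from compound 3 to compound 4 (within the scatter).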

Compound 4, a percentage reported as activity, at one concentration (the size of the read-out at that concentration, not a potency): 6%
Compound 4: middle estimate off by 34 percentage points, on the high side; measured number outside the range, below it.
By their numbers in this assay, from the lowest: compound 4; then compound 1; then compound 3; then compound 2.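

Among these compounds, in (this assay) the earlier compounds only set one aryl substituent against another, while compound 4 adds the plain phenyl as a reference point, and taking away the nitro of the 4-nitrophenyl proves a large loss (a number 44 percentage points lower from compound 3 to compound 4 (beyond the scatter)). The other two comparisons point the same way (a number 59 percentage points lower from compound 2 to compound 4 (beyond the scatter); a number 14 percentage points lower from compound 1 to compound 4 (beyond the scatter)), so all three substituted compounds stand above compound 4, the weakest of the four. Nothing available here explains why these substituents make this difference.

The compounds shown leave open how other groups on this phenyl ring would fare, such as an amine, a carboxylic acid or a chlorine atom. They also leave open whether a nitro and a methoxy on the same ring would add up.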